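Trifluoromethyl in place of fluoro on compound 2

The source may hold more compounds than are shown below. What is called first, only, known or untested is meant among the compounds shown, and "the series" means these compounds.

In a functional assay on RAW264.7 cells (Mus musculus) for inhibition, read by fluorescence, with stated times of 1 h, 24 h and 30 min (on this read-out higher numbers stand for weaker inhibition and lower numbers for stronger inhibition), compound 1 `O=C(/C=C/c1cccc(F)c1)c1ccccc1` gives > 10000 nM, which is a limit of the assay and not a number. Among the compounds with values here, compound 2 `O=C(/C=C/c1cccc(F)c1)c1ccc(O)cc1` gives 9150 nM, the only true number so far. Within the data shown here, the one measured step, an at least 1.0-fold lower number from compound 1 to compound 2 (0.03 log units; that floor lies within the scatter), puts hydroxy in place of hydrogen on an aromatic carbon.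

Compound 3 `O=C(/C=C/c1cccc(C(F)(F)F)c1)c1ccc(O)cc1` keeps that hydroxy and changes a different place: trifluoromethyl in place of fluoro on an aromatic carbon. This is trifluoromethyl in place of fluoro on an aromatic carbon. Among the measured compounds shown here, no measured step touches that position, so the only guide is the small step to compound 2 at 9150 nM. In this assay, the expected change is a 1.5-fold lower number from compound 2 to compound 3 (0.18 log units; within the scatter), and no shift beyond the scatter is expected. For compound 3 the estimated value is 6000 nM, with an expected range from 2000 nM to 10000 nM.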

Compound 3, half-maximal inhibitory concentration: 1440 nM
For compound 3 the middle estimate is 4.2-fold (0.62 log units) above the measured one; the whole stated range lies above it.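

Trifluoromethyl in place of fluoro gives a 6.4-fold lower number from compound 2 to compound 3 (0.80 log units; beyond the scatter) in this assay, so the group at this position, on an aromatic carbon meta to a large group, clearly affects the read-out. With the hydroxy kept in place, this is the first single change shown that moves the result beyond the usual scatter, towards stronger inhibition. Compound 1 stands at a limit of the assay and not at a number, so the earlier step gives only a floor, while this step is the first sized between two true numbers: the limit of > 10000 nM in this assay, at which 1 of the 3 values shown sits.

Whether a methyl, a chloro or an amine at this position would match trifluoromethyl remains open, and the two groups compared here cannot show why the number falls. Also open, as far as these compounds go, is whether the same change would give a similar step on the core of compound 1, which lacks the hydroxy.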